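The source may report more compounds than this note shows. Statements on the series, on what has been measured and on what is new or still open speak of the compounds shown alone.

Measured compounds in the series:

compound 1 `Cc1ncccc1OC[C@@H]1CCCN1C` — 22.9 nM
compound 2 `CCc1cncc(OC[C@@H]2CCCN2C)c1` — 0.32 nM
compound 3 `CN1CCC[C@H]1COc1cc(Br)c[n+]([O-])c1` — 34.8 nM

All three numbers come from an assay on membranes from brain for displacement of a labelled ligand from Neuronal acetylcholine receptor; alpha4/beta2 (Rattus norvegicus); on this read-out higher numbers stand for weaker inhibition and lower numbers for stronger inhibition. On this read-out compound 2 stands lowest of the three, and its distance to both compound 1 and compound 3 is well beyond the scatter of repeated measurements; compound 1 and compound 3 lie close to one another, and nothing more than that is said of the pair, since no single-change step between them is shown.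

Compound 4 `CN1CCC[C@H]1COc1cncc(C(=O)N2CCCC2)c1` has not yet been measured in this assay. It derives from compound 2 by one change: (pyrrolidin-1-yl)carbonyl in place of ethyl on an aromatic carbon. The group that leaves is small and has no hydrogen-bond acceptor; the group that enters is larger, brings one five-membered non-aromatic ring and one hydrogen-bond acceptor, and sits two atoms from the ring nitrogen.

Within the data shown here, no pair of measured compounds differing in one place is available, so the size of this step cannot be read off from the data. The expectation for compound 4 is a step towards a higher number, beyond the scatter, with compound 2 as the reference point at 0.32 nM; the expected step is a 16-fold higher number from compound 2 to compound 4 (1.19 log units; beyond the scatter). Compound 4 is thus estimated at 5 nM, within a range from 1 nM to 30 nM.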

Compound 4, inhibition constant: 19.9 nM
Compound 4: middle estimate off by 4.0-fold (0.60 log units), on the low side; the measured number falls inside the stated range.
By their numbers in this assay, from the lowest: compound 2; then compounds 4, 1 and 3 (each within the scatter of the next).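

In this assay, among these compounds, (pyrrolidin-1-yl)carbonyl in place of ethyl on an aromatic carbon, two atoms from the ring nitrogen, produces a 62-fold higher number from compound 2 to compound 4 (1.79 log units; beyond the scatter) and gives the first single-change reading. The step is large and points towards weaker inhibition, so this position is not indifferent to the group it carries: replacing a small group without a hydrogen-bond acceptor with a larger one that brings a five-membered non-aromatic ring and a hydrogen-bond acceptor changes the number well beyond the scatter. This one step treats the carbonyl and the ring as a single change, and nothing at hand bears on the reason for its size.

The compounds shown leave open whether the carbonyl or the ring carries the step, a question that a primary carboxamide, a dimethylcarboxamide or a carboxylic acid on the same carbon would help to divide. They also leave open how a longer chain such as propyl, or a methoxy group in that place, would read against ethyl.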